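The source may report more compounds than this note shows. Statements on the series, on what has been measured and on what is new or still open speak of the compounds shown alone.

Going by the values given here, compound 2 `Cc1ccc(-c2ccc(NC(=O)CN3CCCC4=C3C(=O)N(C3CC3)C4=O)nn2)cn1` stands as the higher of the two numbers measured so far in an assay on cells for inhibition of Protein-serine O-palmitoleoyltransferase porcupine (Homo sapiens), read by reporter gene assay (a lower number here means a stronger inhibitor, a higher number a weaker inhibitor), where compound 2 gives 12 nM. Compound 1 `CN1C(=O)C2=C(C1=O)N(CC(=O)Nc1ccc(-c3ccccc3)nn1)CCC2`, which carries a methyl on the amide-type nitrogen in the ring and a different group elsewhere on the shared core, gives 1 nM in this assay; the two compounds differ in two places, so their gap cannot be assigned to either change alone. Compound 3 `Cc1ccc(-c2ccc(NC(=O)CN3CCCC4=C3C(=O)N(C)C4=O)nn2)cn1` makes one change to compound 2: methyl in place of cyclopropyl on an amide-type nitrogen in a ring. Among the compounds with values here, no measured pair differs by this change alone, so the size of the step is uncertain. Since compound 1 also carries the methyl and gives 1 nM, a move toward a lower number seems more likely than a higher one, though it may stay within the scatter. The step expected here is a 2.4-fold lower number from compound 2 to compound 3 (0.38 log units; beyond the scatter). Compound 3 is estimated at 5 nM in this assay, within a range from 1.5 nM to 15 nM.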

Compound 3, half-maximal inhibitory concentration in the Protein-serine O-palmitoleoyltransferase porcupine assay: 29 nM
Beside the measured number, compound 3's estimate is 5.8-fold (0.76 log units) below it; measured number outside the range, above it.
By their numbers in the Protein-serine O-palmitoleoyltransferase porcupine assay, from the lowest: compound 1; then compound 2; then compound 3.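

Going by these compounds alone, in the Protein-serine O-palmitoleoyltransferase porcupine assay, methyl in place of cyclopropyl on the amide-type nitrogen in a ring gives a 2.4-fold higher number from compound 2 to compound 3 (0.38 log units; beyond the scatter), the first reading of this change alone, and it shows that the cyclopropyl compound is the stronger inhibitor of this pair. The other single change, 6-methylpyridin-3-yl in place of phenyl on an aromatic carbon, gives a much larger step, a 29-fold higher number from compound 1 to compound 3 (1.46 log units; beyond the scatter), so the phenyl compound is far stronger with methyl on the ring nitrogen. In a physicochemical assay for solubility, measured as thermodynamic solubility, at pH 7.4 (on this read-out higher numbers stand for higher solubility and lower numbers for lower solubility), compound 2 gives 11.1 ug/mL and compound 3 gives 35.5 ug/mL as the more soluble of the pair, so the change that costs some inhibition gains solubility: the measured solubility of compound 2, 11.1 ug/mL, and of compound 3, 35.5 ug/mL, a 3.2-fold higher number (0.50 log units; beyond the scatter)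

Going by these compounds, whether an ethyl group or a longer chain ending in an amine on that nitrogen would keep both the inhibition and the solubility remains open. On these data alone, it is also open whether the cyclopropyl-to-methyl step keeps its size with phenyl on the aromatic carbon.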